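A few compounds are considered here, and "the series" means these few. Any claim that something is new, unique, unknown or untested is made for them only; others in the source may bear on it.

The measured compounds are compound 1 `O=C(NCc1ccc(CNS(=O)(=O)c2ccccc2)cc1)c1ccc(F)cc1`, compound 2 `Cc1ccccc1C(=O)NCc1ccc(CNS(=O)(=O)c2ccccc2)cc1` and compound 3 `COc1cccc(C(=O)NCc2ccc(CNS(=O)(=O)c3ccccc3)cc2)c1`. In an assay on MDA-MB-231 cells for binding affinity to C-X-C chemokine receptor type 4 (Homo sapiens), read by immunofluorescence and microscopy, with stated times of 10 min and 30 min (a higher number here means that more compound is needed for the effect, a lower number that less compound is needed), compound 1 gives 100 nM. In this assay compound 2 gives 1 nM. For compound 3, this assay returns only a limit, > 1000 nM, a point at which one of the three values shown sits (the limit of > 1000 nM in this assay, at which 1 of the 3 values shown sits).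

Compound 3 therefore stands as the weakest of the three, with no exact number of its own; its steps from compound 1 and from compound 2 are both beyond the scatter. The next compound is compound 4 `O=C(NCc1ccc(CNS(=O)(=O)c2ccccc2)cc1)c1ccc(Cl)cc1`, which differs from compound 3 in one place: 4-chlorophenyl in place of 3-methoxyphenyl on a carbonyl carbon. Among the measured compounds shown here, two measured steps bear on this change. The step of an at least 10-fold higher number from compound 1 to compound 3 (1.00 log units; beyond the scatter) shows that moving from 4-fluorophenyl to 3-methoxyphenyl costs heavily, and the step of an at least 1000-fold higher number from compound 2 to compound 3 (3.00 log units; beyond the scatter) is larger still. Compound 4 undoes the first of these moves in kind, replacing 3-methoxyphenyl with a 4-chlorophenyl that closely resembles the 4-fluorophenyl of compound 1. Compound 4 is therefore expected to show a large downward step in this assay, an at least 10-fold lower number from compound 3 to compound 4 (1.00 log units; beyond the scatter). The expected landing point lies near the value of compound 1 rather than the far lower value of compound 2. Compound 4 is estimated at 100 nM, within 30 nM to 600 nM.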

Compound 4, effective concentration (reported as EC, without a stated level of effect): 100 nM
Compound 4: middle estimate and measured number agree at the digits printed, and the stated range covers the measured number.
By their numbers in this assay, from the lowest: compound 2; then compounds 1 and 4 (each within the scatter of the next). At a limit, above all of these: compound 3.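

In this assay, among the compounds shown here, chloro in place of fluoro on an aromatic carbon gives no change at the digits printed from compound 1 to compound 4 (within the scatter), so the 4-fluorophenyl is no longer the only group on this carbonyl carbon known to sit at this level. The 4-chlorophenyl also gives an at least 10-fold lower number from compound 3 to compound 4 (1.00 log units; beyond the scatter) and a 100-fold higher number from compound 2 to compound 4 (2.00 log units; beyond the scatter), which shows that the two halogen-bearing groups share one level while the 2-methylphenyl of compound 2 remains clearly apart from them. The first of these steps gives only a minimum size, since compound 3 has a limit rather than a number: the limit of > 1000 nM in this assay, at which 1 of the 4 values shown sits.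

The compounds shown leave open whether the low number of compound 2 follows from the methyl group itself or from where it sits on the ring, and whether the limit of compound 3 reflects the methoxy group or its place. Also open, on these data alone, is how this carbonyl carbon would tolerate a phenyl ring carrying an amine or a carboxylic acid, or a longer chain in place of the aromatic ring, with the rest of the core unchanged.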